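Aryl versus carbamoylmethyl on the triazole nitrogen

The compounds below may be only part of what the source reports. "The series", "measured", "known", "first", "only" and "open" are said of these compounds alone.

Measured so far in a functional assay on DU-145 cells (Homo sapiens) for inhibition, read by MTT assay, with a stated time of 24 h; a higher number here means a weaker inhibitor, a lower number a stronger inhibitor:
- compound 1, `CCOC(=O)C1=Cc2ccccc2OC1(OCc1cn(CC(=O)NC2CCCCC2)nn1)C(F)(F)F`: compound 1 gives 10200 nM
- compound 2, `CCOC(=O)C1=Cc2ccccc2OC1(OCc1cn(-c2ccc(F)c([N+](=O)[O-])c2)nn1)C(F)(F)F`: compound 2 gives 13200 nM
- compound 3, `CCOC(=O)C1=Cc2ccccc2OC1(OCc1cn(CC(=O)Nc2ccccc2F)nn1)C(F)(F)F`: compound 3 gives 33900 nM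

Compound 3 has the highest number of the three. Its nearest neighbour is compound 2, and the gap is a 2.6-fold higher number from compound 2 to compound 3 (0.41 log units; beyond the scatter); the wider gap is a 3.3-fold higher number from compound 1 to compound 3 (0.52 log units; beyond the scatter). Both of these lie beyond the scatter, so compound 3 is the weakest inhibitor of the set as measured.

Compound 4, `CCOC(=O)C1=Cc2ccccc2OC1(OCc1cn(-c2cccc(C(F)(F)F)c2)nn1)C(F)(F)F`, differs from compound 3 in one place: 3-(trifluoromethyl)phenyl in place of ((2-fluorophenyl)carbamoyl)methyl on an aromatic nitrogen. Among the measured compounds shown here, the step that bears most directly on it is the one from compound 2 to compound 3, where a carbamoylmethyl substituent replaced an aryl group on the same nitrogen and gave a 2.6-fold higher number from compound 2 to compound 3 (0.41 log units; beyond the scatter). Compound 4 reverses that type of change, putting an aryl group back on the triazole nitrogen. The step from compound 1 to compound 2, an aryl in place of a carbamoylmethyl, was only a 1.3-fold higher number from compound 1 to compound 2 (0.11 log units; within the scatter), so an aryl on this nitrogen is not expected to carry a penalty of its own.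

The expected step is therefore a modest lowering, a 2.6-fold lower number from compound 3 to compound 4 (0.42 log units; beyond the scatter), bringing compound 4 close to compound 2. Compound 4 is estimated at 13000 nM, with a range of 6000 nM to 30000 nM.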

Compound 4, half-maximal inhibitory concentration: > 150000 nM
Compound 4: a limit, no number (the forecaster's own chance of this, stated with the estimate: 5%); middle value at least 11-fold (1.06 log units) from the limit.
By their numbers in this assay, from the lowest: compounds 1 and 2 (each within the scatter of the next); then compound 3. At a limit, above all of these: compound 4.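

In this assay compound 4 stands at a limit of the assay and not at a number: the limit of > 150000 nM in this assay, at which 1 of the 4 values shown sits.

The earlier compounds shown here suggested that an aryl group on this nitrogen carried no penalty of its own, yet exchanging one aryl group for another, 3-(trifluoromethyl)phenyl in place of 4-fluoro-3-nitrophenyl, gives an at least 11-fold higher number from compound 2 to compound 4 (1.05 log units; beyond the scatter), so the kind of aryl group matters far more than the choice between aryl and carbamoylmethyl seen so far. Against the carbamoylmethyl groups the same aryl group gives an at least 14-fold higher number from compound 1 to compound 4 (1.16 log units; beyond the scatter) and an at least 4.4-fold higher number from compound 3 to compound 4 (0.64 log units; beyond the scatter), which makes compound 4 the weakest inhibitor of the four and shows this position to have a much wider span than the modest steps among compounds 1, 2 and 3 revealed.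

The compounds shown do not separate the effect of the trifluoromethyl group from that of losing the nitro and fluoro substituents of compound 2, and a plain phenyl would bear on that directly. From the compounds shown here alone, whether an amine or a carboxylic acid in place of the trifluoromethyl, or a longer chain on this nitrogen, would return the number towards that of compound 2 also remains open.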